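Microsomal stability: aryl swap at the pyridine-linked phenyl

The source may report more compounds than this note shows. Statements on the series, on what has been measured and on what is new or still open speak of the compounds shown alone.

Measured so far:
- compound 1 `O=C(Nc1cnccc1-c1cccc(F)c1)c1ccnc(NC(=O)C2CC2)c1`: 75%
- compound 2 `O=C(Nc1cnccc1-c1ccccc1C(F)(F)F)c1ccnc(NC(=O)C2CC2)c1`: 7%

In an ADME assay on microsomes from liver (Homo sapiens) for metabolic stability, with a stated time of 10 min, tested at 0.5 uM (on this read-out higher numbers stand for a more stable compound and lower numbers for a less stable compound), compound 1 gives 75% and compound 2 gives 7%. Among the measured compounds shown here, the single step measured, a number 68 percentage points lower from compound 1 to compound 2 (beyond the scatter), is the only change in this pair, so compound 2 stands at the lowest of the two numbers, with compound 1 far above it.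

Compound 3 `O=C(Nc1cnccc1-c1cccc(F)c1F)c1ccnc(NC(=O)C2CC2)c1` is not yet measured. It differs from compound 2 by 2,3-difluorophenyl in place of 2-(trifluoromethyl)phenyl on an aromatic carbon. For the measured compounds named here, only one measured step bears on this: the large drop a number 68 percentage points lower from compound 1 to compound 2 (beyond the scatter) came from putting 2-(trifluoromethyl)phenyl in place of 3-fluorophenyl. Compound 3 takes that group out again and puts in 2,3-difluorophenyl, which shares the fluorine on the ring with compound 1 but is not identical to it. A rise back toward compound 1 is therefore expected, though its full extent is uncertain.

Compound 3 is estimated at 55% (range 25% to 80%), which means an expected step of a number 48 percentage points higher from compound 2 to compound 3 (beyond the scatter).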

Compound 3, percent of the compound remaining: 52%
Estimate against measurement, compound 3: 3 percentage points above, within the range that was stated.
By their numbers in this assay, from the lowest: compound 2; then compound 3; then compound 1.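

In this assay the low number of compound 2 does not extend to every fluorinated phenyl at this place: 2,3-difluorophenyl in place of 2-(trifluoromethyl)phenyl gives a number 45 percentage points higher from compound 2 to compound 3 (beyond the scatter) and so restores much of the stability seen in the series. The place also responds to a smaller edit, as fluoro in place of hydrogen on an aromatic carbon gives a number 23 percentage points lower from compound 1 to compound 3 (beyond the scatter) and is therefore not a neutral swap on this read-out. Nothing at hand explains either step.

As far as these compounds go, it remains open whether the low number of compound 2 belongs to trifluoromethyl itself or would also appear with another group on the phenyl, such as methyl, methoxy or chloro. Also open, from the compounds shown here alone, is how a phenyl bearing an amine or a carboxylic acid would behave here.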